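The source may hold more compounds than are shown below. What is called first, only, known or untested is meant among the compounds shown, and "the series" means these compounds.

Among the compounds with values here, compound 1 `NCc1ccc(NC(=O)N(CCCCO)Cc2ccc(C(=O)NO)cc2)cc1` gives 1470 nM in an assay on HEK293 cells for inhibition of histone deacetylase 7 (Homo sapiens), read by fluorescence, with stated times of 10 min and 30 min (a higher number here means a weaker inhibitor, a lower number a stronger inhibitor), the lowest of the two numbers so far. Compound 2 `CCCCN(Cc1ccc(C(=O)NO)cc1)C(=O)Nc1ccc(CN)cc1` gives 9000 nM in this assay, a 6.1-fold higher number from compound 1 to compound 2 (0.79 log units; beyond the scatter). Compound 3 `O=C(NO)c1ccc(CN(CCCCO)C(=O)Nc2ccccc2)cc1` is the next question: it is compound 1 with hydrogen in place of aminomethyl on an aromatic carbon. The only measured step, from compound 1 to compound 2, touches the hydroxybutyl chain and not the aminomethyl group, so no measured step bears on this change and its size cannot be read from the pair shown. Compound 3 is therefore expected near 3000 nM, between 1000 nM and 9000 nM, with a 2.0-fold higher number from compound 1 to compound 3 (0.31 log units; beyond the scatter) the estimated step.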

Compound 3, half-maximal inhibitory concentration: 1930 nM
Compound 3: middle estimate off by 1.6-fold (0.19 log units), on the high side; low and high end bracket the measured number.
By their numbers in this assay, from the lowest: compounds 1 and 3 (each within the scatter of the next); then compound 2.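

At this place on the aromatic ring, para to a large group, going from 4-(aminomethyl)phenyl to phenyl gives a 1.3-fold higher number from compound 1 to compound 3 (0.12 log units; within the scatter) in this assay, so with the hydroxybutyl chain present, aminomethyl makes no resolvable difference. Within the data shown here, the hydroxy change on the chain, a 6.1-fold higher number from compound 1 to compound 2 (0.79 log units; beyond the scatter), remains the only one of the two steps beyond the scatter. No available evidence accounts for this result.

As far as these compounds go, whether aminomethyl matters any more on the butyl chain of compound 2 stays open. Also open, from the compounds shown here alone, is how a carboxylic acid or a longer aminoalkyl chain would read on this aromatic carbon.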